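The source may hold more compounds than are shown below. What is called first, only, known or untested is meant among the compounds shown, and "the series" means these compounds.

Of the compounds shown here, three built on one shared core have been tested in a functional assay on the whole organism (strain Wistar) for inhibition, with Rattus norvegicus as the target, read by paw edema, with a stated time of 24 h, at a dose of 100 mg/kg; on this read-out higher numbers stand for more inhibition at the one dose given (going by the name of the read-out) and lower numbers for less inhibition. Compound 1 `COc1cc2c(cc1OC)C(CC(=O)Nc1ccc(Cl)cc1)CC2` gives 70%, compound 2 `COc1cc2c(cc1OC)C(CC(=O)Nc1ccc(Br)cc1)CC2` gives 66.7%, and compound 3 `COc1cc2c(cc1OC)C(CC(=O)Nc1cccc(C)c1)CC2` gives 41.7%. Compound 3 stands lowest of the three: the step of a number 28.3 percentage points lower from compound 1 to compound 3 (beyond the scatter) and the step of a number 25 percentage points lower from compound 2 to compound 3 (beyond the scatter) both lie beyond the scatter, while the step of a number 3.3 percentage points lower from compound 1 to compound 2 (within the scatter) does not, so the two halogen-bearing compounds sit together above compound 3.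

Compound 4 `COc1ccccc1NC(=O)CC1CCc2cc(OC)c(OC)cc21` has not been measured. It differs from compound 3 in one place: 2-methoxyphenyl in place of 3-methylphenyl on an amide-type nitrogen. Within the data shown here, the only measured steps that alter the group on the amide-type nitrogen are the two leading to compound 3, and each was a modest drop on exchanging a halogen-bearing phenyl for 3-methylphenyl. Among the measured compounds shown here, no measured compound carries 2-methoxyphenyl, and no measured step swaps 3-methylphenyl for anything else, so there is no direct precedent for this change. The available steps show this group can shift the read-out by modest amounts but offer no direction here. Compound 4 is therefore expected to give about 45%, with a likely range from 20% to 70%. The expected step is a number 3.3 percentage points higher from compound 3 to compound 4 (within the scatter), within the scatter.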

Compound 4, a percentage reported as inhibition, in the whole organism at one dose (the size of the read-out at that dose, not a potency): 30%
The estimate for compound 4 lay 15 percentage points above the measured number; measured number inside the range.
By their numbers in this assay, from the lowest: compound 4; then compound 3; then compounds 2 and 1 (each within the scatter of the next).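

Among these compounds, the change to 2-methoxyphenyl on the amide-type nitrogen in this assay gives a number 11.7 percentage points lower from compound 3 to compound 4 (beyond the scatter), so this position can lose further ground even when the group leaving carries no halogen, which the earlier steps could not show. Set against the halogen-bearing compounds, the same position gives a number 36.7 percentage points lower from compound 2 to compound 4 (beyond the scatter) and a number 40 percentage points lower from compound 1 to compound 4 (beyond the scatter), both large steps, so the choice of group here can move the read-out much further than the modest drops seen so far, and among these four compounds, none goes against the two halogen-bearing groups standing highest. The entering group brings an oxygen and a hydrogen-bond acceptor, but nothing measured here connects either of these to the lower number.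

On these data alone, it remains open whether a phenyl group carrying an amine or a carboxylic acid, or a longer chain on the amide-type nitrogen, would stay with the halogen-bearing compounds or fall with compound 3 and compound 4. The read-out also gives the size of the effect at a single dose, so it leaves open whether this order would hold at other doses.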